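Notes: 2-methoxyphenyl in place of 3-cyanophenyl on the carbonyl carbon

The source may hold more compounds than are shown below. What is called first, only, known or untested is meant among the compounds shown, and "the series" means these compounds.

In a functional assay on HepG2 cells (Homo sapiens) for inhibition, read by MTT assay (on this read-out higher numbers stand for weaker inhibition of growth and lower numbers for stronger inhibition of growth), compound 1 `COc1cc2oc(-c3cccc(NC(=O)c4ccccc4)c3)cc(=O)c2c(OC)c1OC` gives 11700 nM, compound 2 `COc1cc2oc(-c3cccc(NC(=O)c4ccc(C#N)cc4)c3)cc(=O)c2c(OC)c1OC` gives 10200 nM, and compound 3 `COc1cc2oc(-c3cccc(NC(=O)c4cccc(C#N)c4)c3)cc(=O)c2c(OC)c1OC` gives 11900 nM. Compound 3 therefore stands level with the other two, with no separation beyond the scatter.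

Compound 4 `COc1ccccc1C(=O)Nc1cccc(-c2cc(=O)c3c(OC)c(OC)c(OC)cc3o2)c1` has 2-methoxyphenyl in place of 3-cyanophenyl on a carbonyl carbon.

Among the measured compounds shown here, three measured steps touch this same group. Cyano in place of hydrogen gave a 1.1-fold lower number from compound 1 to compound 2 (0.06 log units; within the scatter) and a 1.0-fold higher number from compound 1 to compound 3 (0.01 log units; within the scatter), while 3-cyanophenyl in place of 4-cyanophenyl gave a 1.2-fold higher number from compound 2 to compound 3 (0.07 log units; within the scatter). For the measured compounds named here, all three are small, but no measured compound carries 2-methoxyphenyl, so the evidence is indirect and the range must stay wide.

No change beyond the scatter is expected in this assay, and no direction is favoured. The expected step is a 1.1-fold lower number from compound 3 to compound 4 (0.03 log units; within the scatter). For compound 4 the estimated value is 11000 nM, with an expected range of 5000 nM to 25000 nM.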

Compound 4, concentration for 50% growth inhibition: 7530 nM
The estimate for compound 4 lay 1.5-fold (0.16 log units) above the measured number, and the stated range covers the measured number.
By their numbers in this assay, from the lowest: compounds 4, 2, 1 and 3 (each within the scatter of the next).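

In this assay, among the compounds shown here, methoxy on this aryl group joins hydrogen and nitrile as a substituent that produces no separation from the earlier compounds (steps: a 1.6-fold lower number from compound 3 to compound 4 (0.20 log units; within the scatter); a 1.4-fold lower number from compound 2 to compound 4 (0.13 log units; within the scatter); a 1.6-fold lower number from compound 1 to compound 4 (0.19 log units; within the scatter)). Across the four compounds, the carbonyl carbon has so far carried 2-methoxyphenyl, phenyl, 3-cyanophenyl and 4-cyanophenyl without any step passing beyond the scatter, so none of these groups can be ranked. No measurement here offers a reason for the result.

As far as these compounds go, whether an amine or a carboxylic acid on this aryl group, or a longer chain in place of methoxy, would produce a step beyond the scatter remains open. Also open, from the compounds shown here alone, is whether any change to the amide hydrogen or the shared core would shift the number more than these aryl changes have.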